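A halogen swap on the carbonyl-bound phenyl ring

This account rests on a few compounds, and the source may have more. Where it says the series, first, only, none or still open, it means among the compounds named here.

Measured so far:
- compound 1, `Cc1ccc(OCC(=O)NNC(=O)c2cc3ccccc3oc2=O)c(C(=O)c2ccccc2Cl)c1`: 54800 nM
- compound 2, `Cc1ccc(OCC(=O)NNC(=O)c2cc3ccccc3oc2=O)c(C(=O)c2cccc(Br)c2)c1`: 71900 nM
- compound 3, `Cc1ccc(OCC(=O)NNC(=O)c2cc3ccccc3oc2=O)c(C(=O)c2ccc(Br)cc2)c1`: 95500 nM

All three compounds share one core and differ only in the halogenated phenyl ring that sits on a carbonyl carbon. In a functional assay on DLA cells (Mus musculus) for cytotoxicity, read by trypan blue exclusion, with a stated time of 48 h (a higher number here means a weaker inhibitor, a lower number a stronger inhibitor), compound 1 gives the lowest of the three numbers, but the gap to compound 2, a 1.3-fold higher number from compound 1 to compound 2 (0.12 log units; within the scatter), and the gap to compound 3, a 1.7-fold higher number from compound 1 to compound 3 (0.24 log units; within the scatter), both lie within the scatter of repeated measurements, so the three compounds cannot be told apart on these data.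

Compound 4, `Cc1ccc(OCC(=O)NNC(=O)c2cc3ccccc3oc2=O)c(C(=O)c2ccc(F)cc2)c1`, is not yet measured. It differs from compound 1 in one place: 4-fluorophenyl in place of 2-chlorophenyl on a carbonyl carbon. The two measured steps that bear on this change are those from compound 1 to compound 2 and from compound 1 to compound 3, in which a bromine replaced the chlorine and moved to another position on the same ring; neither moved the number beyond the scatter. Since a fluorine in the 4-position is again a change of halogen and position on this ring, the expectation is a step of about a 1.2-fold higher number from compound 1 to compound 4 (0.07 log units; within the scatter) in this assay, not beyond the scatter. Compound 4 is therefore estimated at 65000 nM, with a range from 30000 nM to 140000 nM.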

Compound 4, half-maximal inhibitory concentration: 46100 nM
The estimate for compound 4 lay 1.4-fold (0.15 log units) above the measured number; low and high end bracket the measured number.
By their numbers in this assay, from the lowest: compounds 4, 1, 2 and 3 (each within the scatter of the next, the first and the last beyond it).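

In this assay, going by these compounds alone, the most informative step is the one where only the halogen changes and its place on the ring stays the same: fluoro in place of bromo on an aromatic carbon gives a 2.1-fold lower number from compound 3 to compound 4 (0.32 log units; beyond the scatter) and is the only step to compound 4 that clears the scatter. The other two steps do not separate the new compound, as a 1.2-fold lower number from compound 1 to compound 4 (0.08 log units; within the scatter) and a 1.6-fold lower number from compound 2 to compound 4 (0.19 log units; within the scatter) both remain within the scatter, so the 4-fluorophenyl group cannot be told apart from the 2-chlorophenyl or 3-bromophenyl group on this carbonyl carbon. The halogen can therefore make a small difference on this ring, but that finding rests on a single pair of compounds, and nothing measured here accounts for it.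

Going by these compounds, all four compounds carry one halogen on this ring, so it remains open whether a halogen is needed at all, a question that a plain phenyl ring or a ring bearing an amine or a methoxy group would address. On these data alone, it is also open whether the gap between bromo and fluoro would persist with the two halogens elsewhere on the ring, as in the 2-fluorophenyl or 3-fluorophenyl groups.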